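The compounds below may be only part of what the source reports. "The series", "measured", "known", "first", "only" and "open" are said of these compounds alone.

Compound 1 `Cc1ccc(S(=O)(=O)c2cnc3c(F)cccc3c2N2CCC(C)CC2)cc1`: 93%
Compound 2 `Cc1ccc(S(=O)(=O)c2cnc3ccc(Cl)cc3c2N2CCC(C)CC2)cc1C`: 84%

In an assay on isolated protein for displacement of a labelled ligand from metabotropic glutamate receptor 5 (Homo sapiens), with a stated time of 60 min, tested at 1 uM (on this read-out lower numbers stand for less inhibition and higher numbers for more inhibition at the one concentration tested (going by the name of the read-out)), compound 1 gives 93%, the highest of the two numbers, while compound 2 gives 84%, which lies within the scatter of it. Compound 3 `CC1CCN(c2c(S(=O)(=O)c3cc(F)cc(F)c3)cnc3c(F)cccc23)CC1` differs from compound 1 in one place: 3,5-difluorophenyl in place of 4-methylphenyl on a sulfonyl sulfur. Going by the values given here, no measured pair shows a change of this kind, so its size is unknown. Since both measured compounds sit near the top of the read-out, a step of no more than the scatter is expected, if anything slightly downward. Compound 3 is expected to give 85%, with a range from 65% to 97%. The estimated step is a number 8 percentage points lower from compound 1 to compound 3 (within the scatter).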

Compound 3, a percentage reported as inhibition, at one concentration (the size of the read-out at that concentration, not a potency): 9%
Beside the measured number, compound 3's estimate is 76 percentage points above it, outside the stated range (below it).
By their numbers in this assay, from the lowest: compound 3; then compounds 2 and 1 (each within the scatter of the next).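

In this assay, 3,5-difluorophenyl in place of 4-methylphenyl on a sulfonyl sulfur gives a number 84 percentage points lower from compound 1 to compound 3 (beyond the scatter). This is the first single-place change shown, and it makes clear that the read-out depends strongly on the aryl group held at this position of the shared core. No evidence is available on why the step is so large.

On these data alone, it remains open whether losing the methyl or gaining the two fluorines matters more, and whether a plain phenyl or a 4-methoxyphenyl would keep the high number.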